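The compounds below may be only part of what the source reports. "The series", "measured", "known", "first", "only" and "open" are said of these compounds alone.

The measured compounds and their values:

Compound 1 `O=C(Nc1cccc(-c2oc3cc(-c4ccc(F)cc4)ccc3c(=O)c2O)c1)c1ccc(F)cc1F`: in a functional assay on A549 cells (Homo sapiens) for antiproliferative activity, read by CCK-8 assay, with a stated time of 72 h (on this read-out lower numbers stand for stronger inhibition and higher numbers for weaker inhibition), compound 1 gives 20500 nM.
Compound 2 `COc1cc(OC)cc(C(=O)Nc2cccc(-c3oc4cc(-c5ccc(F)cc5)ccc4c(=O)c3O)c2)c1`: in this assay compound 2 gives 2390 nM.
Compound 3 `O=C(Nc1cccc(-c2oc3cc(-c4ccc(F)cc4)ccc3c(=O)c2O)c1)c1ccc(Cl)nc1`: in this assay compound 3 gives 3580 nM.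

Compound 1 stands highest of the three numbers, that is, as the weakest inhibitor of the set. Its nearest neighbour is compound 3, and the step of a 5.7-fold lower number from compound 1 to compound 3 (0.76 log units; beyond the scatter) lies beyond the scatter; the step to compound 2, an 8.6-fold lower number from compound 1 to compound 2 (0.93 log units; beyond the scatter), is larger still. Between compounds 2 and 3 the step of a 1.5-fold higher number from compound 2 to compound 3 (0.18 log units; within the scatter) is within the scatter, so nothing separates them.

Compound 4 `O=C(Nc1cccc(-c2oc3cc(-c4ccc(F)cc4)ccc3c(=O)c2O)c1)c1cc(F)cc(F)c1` differs from compound 1 in one place: 3,5-difluorophenyl in place of 2,4-difluorophenyl on a carbonyl carbon. Both measured steps that start from compound 1 replace the same 2,4-difluorophenyl, and both gave lower numbers, an 8.6-fold lower number from compound 1 to compound 2 (0.93 log units; beyond the scatter) and a 5.7-fold lower number from compound 1 to compound 3 (0.76 log units; beyond the scatter). Among the compounds with values here, no measured step exchanges one difluorophenyl for another, so the bearing of these steps on compound 4 is indirect, and a smaller change than either is the safer expectation. Compound 4 is therefore expected to show a lower number than compound 1, a 2.9-fold lower number from compound 1 to compound 4 (0.47 log units; beyond the scatter), with an estimated value of 7000 nM in a range from 2500 nM to 20000 nM.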

Compound 4, half-maximal inhibitory concentration: 7620 nM
Compound 4: the middle estimate sits 1.1-fold (0.04 log units) below what was measured; the measured number falls inside the stated range.
By their numbers in this assay, from the lowest: compounds 2 and 3 (each within the scatter of the next); then compound 4; then compound 1.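

Compound 4 carries the same atoms as compound 1, joined differently, and in this assay the exchange of 2,4-difluorophenyl for 3,5-difluorophenyl on the carbonyl carbon gives a 2.7-fold lower number from compound 1 to compound 4 (0.43 log units; beyond the scatter), so at this position the placement of the fluorines alone moves the number beyond the scatter. The 3,5-difluorophenyl group still leaves compound 4 short of the other two replacements, with a 2.1-fold higher number from compound 3 to compound 4 (0.33 log units; beyond the scatter) and a 3.2-fold higher number from compound 2 to compound 4 (0.50 log units; beyond the scatter), and the second of these steps shows that the 3,5-difluorophenyl and 3,5-dimethoxyphenyl groups are not interchangeable here, although both names carry the same numbering. Nothing among the available data offers an explanation for these differences.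

From the compounds shown here alone, it remains open which of the fluorines in compound 1 goes with its higher number, and how an unsubstituted phenyl, a 2-fluorophenyl or a 4-fluorophenyl group would stand on the same carbonyl carbon. Also open, going by these compounds, is whether an amine or a carboxylic acid on this ring would hold the number near those of compounds 2 and 3, or move it elsewhere.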